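A few compounds are considered here, and "the series" means these few. Any claim that something is new, unique, unknown or untested is made for them only; others in the source may bear on it.

Compound 1 `O=C(O)c1cc(-n2ccnn2)ccc1O` carries a 1H-1,2,3-triazol-1-yl group on the shared core. In a functional assay on the whole organism for inhibition, with Rattus norvegicus as the target, read by paw edema (on this read-out higher numbers stand for an effect only at larger amounts of compound and lower numbers for an effect already at smaller amounts), compound 1 gives 150 mg/kg, the highest of the three numbers recorded, though every other compound sits within the scatter of it. Compound 2 `O=C(O)c1cc(-n2ccnc2)ccc1O` gives 75 mg/kg in this assay, and compound 3 `O=C(O)c1cc(-c2cscn2)ccc1O` gives 95 mg/kg. The steps are all small: a 2.0-fold lower number from compound 1 to compound 2 (0.30 log units; within the scatter), a 1.6-fold lower number from compound 1 to compound 3 (0.20 log units; within the scatter) and a 1.3-fold higher number from compound 2 to compound 3 (0.10 log units; within the scatter).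

Compound 4 `O=C(O)c1cc(-c2cocn2)ccc1O` differs from compound 1 as follows: 1,3-oxazol-4-yl in place of 1H-1,2,3-triazol-1-yl on an aromatic carbon. The step that bears most directly on this change is the one in which a ring attached through carbon, 1,3-thiazol-4-yl, replaced the same 1H-1,2,3-triazol-1-yl group, namely a 1.6-fold lower number from compound 1 to compound 3 (0.20 log units; within the scatter); the exchange of 1H-1,2,3-triazol-1-yl for 1H-imidazol-1-yl, a 2.0-fold lower number from compound 1 to compound 2 (0.30 log units; within the scatter), was of similar size. Since every swap of the five-membered ring so far stayed within the scatter, no step beyond the scatter is expected for compound 4 in this assay, with at most a slight lowering, a 1.4-fold lower number from compound 1 to compound 4 (0.15 log units; within the scatter). Compound 4 is therefore estimated at 105 mg/kg, within the range 50 mg/kg to 220 mg/kg.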

Compound 4, dose for half-maximal effect: 110 mg/kg
The estimate for compound 4 lay 1.0-fold (0.02 log units) below the measured number; low and high end bracket the measured number.
By their numbers in this assay, from the lowest: compounds 2, 3, 4 and 1 (each within the scatter of the next).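

In this assay, replacing the 1H-1,2,3-triazol-1-yl group with 1,3-oxazol-4-yl gives a 1.4-fold lower number from compound 1 to compound 4 (0.13 log units; within the scatter), and the same group in place of 1,3-thiazol-4-yl gives a 1.2-fold higher number from compound 3 to compound 4 (0.06 log units; within the scatter), while in place of 1H-imidazol-1-yl it gives a 1.5-fold higher number from compound 2 to compound 4 (0.17 log units; within the scatter). A fourth five-membered aromatic ring, meta to the carboxy group and para to the hydroxy group, thus stays within the scatter of all three earlier rings, so this read-out does not separate the four rings at this position. Nothing measured here accounts for this lack of separation.

Going by these compounds, it remains open whether a group of another kind at this position, such as an amine, a carboxylic acid, a phenyl ring or a longer alkyl chain, would produce a step beyond the scatter. On these data alone, the contribution of the carboxy and hydroxy groups also remains open, as both stand unchanged in all four compounds.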